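The source may report more compounds than this note shows. Statements on the series, on what has been measured and on what is new or still open speak of the compounds shown alone.

Compound 1 `O=C(NO)c1ccc(NCc2nc(-c3ccc(Cl)cc3)nn2-c2ccccc2)cc1`: 5970 nM
Compound 2 `O=C(NO)c1ccc(NCc2nc(-c3ccccc3)nn2-c2cccc(Cl)c2)cc1`: 13700 nM
Compound 3 `Cc1cccc(-n2nc(-c3ccccc3)nc2CNc2ccc(C(=O)NO)cc2)c1`: 13200 nM

In a functional assay on MGC-803 cells (Homo sapiens) for antiproliferative activity, read by MTT assay, with a stated time of 72 h (on this read-out lower numbers stand for stronger inhibition and higher numbers for weaker inhibition), compound 1 has the lowest of these three numbers, and the numbers of compound 2 and compound 3 lie above it, beyond the scatter. Compound 4 `O=C(NO)c1ccc(NCc2nc(-c3ccccc3Cl)nn2-c2ccccc2)cc1` differs from compound 1 in one place: 2-chlorophenyl in place of 4-chlorophenyl on an aromatic carbon. Among the measured compounds shown here, the only measured step, a 1.0-fold lower number from compound 2 to compound 3 (0.02 log units; within the scatter), is methyl in place of chloro, stays within the scatter and does not test this change. For the measured compounds named here, no measured pair shifts the chlorine on this ring. The expectation therefore stays close to compound 1 at 5970 nM, leaning slightly towards higher numbers. The expected change is a 1.4-fold higher number from compound 1 to compound 4 (0.15 log units; within the scatter), which is no step beyond the scatter. Compound 4 is estimated at 8500 nM, within a range of 3500 nM to 19000 nM.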

Compound 4, half-maximal inhibitory concentration: > 20000 nM
Compound 4: a limit, no number; the forecaster's own chance of this, stated with the estimate: 3%; middle value at least 2.3-fold (0.37 log units) away from the limit.
By their numbers in this assay, from the lowest: compound 1; then compounds 3 and 2 (each within the scatter of the next). At a limit, above all of these: compound 4.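

In this assay, 2-chlorophenyl in place of 4-chlorophenyl, on an aromatic carbon between two ring nitrogen atoms, gives an at least 3.3-fold higher number from compound 1 to compound 4 (0.52 log units; beyond the scatter). Compound 4 gives > 20000 nM, which is a limit of the assay and not a number. Among the compounds shown here, no earlier pair changed this group, and this one shows that, with the same atoms joined differently, the place of the chlorine on this ring counts beyond the scatter.

As far as these compounds go, how far compound 4 lies past its limit stays open: the limit of > 20000 nM in this assay, at which 1 of the 4 values shown sits. Also open, from the compounds shown here alone, is how a methoxy group or an amine in place of this chlorine would read.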